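A few compounds are considered here, and "the series" means these few. Any claim that something is new, unique, unknown or untested is made for them only; others in the source may bear on it.

Compound 2 (`O=C1NC(=O)/C(=C\c2cccc(Br)c2)N1`) carries a bromo group on the aromatic ring of the shared core. In a functional assay on the whole organism with Rattus norvegicus as the target, in the maximal electroshock model (on this read-out lower numbers stand for an effect already at smaller amounts and higher numbers for an effect only at larger amounts of compound), compound 2 gives only a limit of the assay, > 50 mg/kg, and not a number. Compound 1 (`O=C1NC(=O)/C(=C\c2cccc(Cl)c2)N1`) differs from it in one place, and in this assay compound 1 gives about 50 mg/kg. The step of a number no lower from compound 1 to compound 2 (the limit leaves the size open) is therefore open in size, as the limit of > 50 mg/kg in this assay, at which 1 of the 2 values shown sits, records. Compound 3 (`O=C1NC(=O)/C(=C\c2cccc(C(F)(F)F)c2)N1`) is not yet measured; it differs from compound 2 by trifluoromethyl in place of bromo on an aromatic carbon. Among the measured compounds shown here, no measured step covers a trifluoromethyl group, so the only guide is the open step just described, which gives neither a direction nor a size. The expected step that the limit leaves unreadable from compound 2 to compound 3 is accordingly small or none beyond the scatter. For compound 3 in this assay the estimate is 60 mg/kg, within a range from 30 mg/kg to 150 mg/kg, with a fair chance that again only a limit is reported.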

Compound 3, dose for half-maximal effect: about 50 mg/kg
Estimate against measurement, compound 3: 1.2-fold (0.08 log units) above, within the range that was stated.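

In this assay, trifluoromethyl, with its 4 heavy atoms, can stand on this aromatic carbon in place of chloro with no change at the digits printed from compound 1 to compound 3 (within the scatter). Among the compounds shown here, this gives the first readable comparison at this position, as the only earlier step ended in a limit, and it shows that these two groups cannot be told apart on this read-out. The step of a number no higher from compound 2 to compound 3 (the limit leaves the size open) cannot be read, nor can the other step involving compound 2, and bromo therefore cannot be ranked against either group, because compound 2 gives only a limit of the assay and not a number: the limit of > 50 mg/kg in this assay, at which 1 of the 3 values shown sits.

The compounds shown leave open whether the read-out would stay the same with an amine, a carboxylic acid or a nitrile on this aromatic carbon. They also leave open what a longer chain would do there.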